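Propyl in Place of Isopropyl on the Side Chain

The compounds below may be only part of what the source reports. "The series", "measured", "known", "first", "only" and "open" are said of these compounds alone.

Compound 3 `COc1cccc(Nc2nc(Oc3cccc(NC(=O)/C=C/C(C)C)c3)c3sccc3n2)c1` gives 27000 nM in a functional assay on HeLa cells (Homo sapiens) for inhibition, read by MTT assay, with a stated time of 72 h (a higher number here means a weaker inhibitor, a lower number a stronger inhibitor), the highest of the three numbers, yet both neighbours lie within the scatter: compound 2 `COc1cccc(Nc2nc(Oc3cccc(NC(=O)C=C(C)C)c3)c3sccc3n2)c1` gives 26100 nM and compound 1 `C/C=C/C(=O)Nc1cccc(Oc2nc(Nc3cccc(OC)c3)nc3ccsc23)c1` gives 20100 nM. The steps of a 1.3-fold higher number from compound 1 to compound 2 (0.11 log units; within the scatter), a 1.3-fold higher number from compound 1 to compound 3 (0.13 log units; within the scatter) and a 1.0-fold higher number from compound 2 to compound 3 (0.01 log units; within the scatter) all stay within the scatter. Compound 4 `CCC/C=C/C(=O)Nc1cccc(Oc2nc(Nc3cccc(OC)c3)nc3ccsc23)c1` differs from compound 3 by propyl in place of isopropyl on a double-bonded chain carbon bound to a double-bonded chain carbon. The three measured steps, which all vary the same chain on the carbonyl carbon, bear on this change, and none of them moved the number beyond the scatter. A step within the scatter is therefore expected in this assay, a 1.1-fold lower number from compound 3 to compound 4 (0.03 log units; within the scatter). Compound 4 is expected to give 25000 nM, within a range from 11000 nM to 55000 nM.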

Compound 4, half-maximal inhibitory concentration: 7730 nM
For compound 4 the middle estimate is 3.2-fold (0.51 log units) above the measured one, outside the stated range (below it).
By their numbers in this assay, from the lowest: compound 4; then compounds 1, 2 and 3 (each within the scatter of the next).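

In this assay, among the compounds shown here, the arrangement of the same three carbons proved to matter at this place: propyl in place of isopropyl gave a 3.5-fold lower number from compound 3 to compound 4 (0.54 log units; beyond the scatter), the first step beyond the scatter. The unbranched chain also stands apart from the other two compounds, with a 3.4-fold lower number from compound 2 to compound 4 (0.53 log units; beyond the scatter) and a 2.6-fold lower number from compound 1 to compound 4 (0.42 log units; beyond the scatter), the latter for ethyl in place of hydrogen on a saturated chain carbon. Nothing given here accounts for this difference.

On these data alone, whether a longer chain, such as hexyl, would lower the number further remains open. So does whether an amine or a carboxylic acid on the propyl chain would keep this step.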